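Pentyl on selenium: from compound 3 toward compound 4

The compounds below may be only part of what the source reports. "The series", "measured", "known", "first", "only" and "open" are said of these compounds alone.

Compound 1 `CCCCC[Se]c1nc([Se]CCCCC)c2ccccc2n1` carries two pentylseleno groups on the shared core. In a functional assay on HT-29 cells (Homo sapiens) for cytotoxicity, read by MTT assay, with a stated time of 72 h (a lower number here means a stronger inhibitor of growth, a higher number a weaker inhibitor of growth), compound 1 reports only a limit, > 100000 nM, which is a limit of the assay and not a number (the limit of > 100000 nM in this assay, at which 1 of the 3 values shown sits). Among the compounds with values here, compound 2 `CCCCC[Se]c1nc(NCc2ccccc2)c2ccccc2n1` keeps one pentylseleno group and gives 72700 nM; the step of an at least 1.3-fold lower number from compound 1 to compound 2 (0.13 log units; that floor lies within the scatter) is the only measured single change in the set. Compound 3 `Nc1nc([SeH])nc2ccccc12`, with an amino group and a selenium bearing only hydrogen, gives 52200 nM; this sits within the scatter of compound 2, so no order between the two can be stated.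

Compound 4 `CCCCC[Se]c1nc(N)c2ccccc2n1` differs from compound 3 by pentyl in place of hydrogen on a selenium. Within the data shown here, no measured step covers this change: the step from compound 1 to compound 2 alters a substituent on an aromatic carbon, not on a selenium. Among the measured compounds shown here, the only guidance is that every compound in the set, with or without a pentyl on selenium, sits near the upper end of this assay.

Compound 4 is therefore expected to stay at about the level of compound 3, with a 1.1-fold higher number from compound 3 to compound 4 (0.06 log units; within the scatter) not expected to exceed the scatter. The estimate for compound 4 is 60000 nM, within the range 20000 nM to 150000 nM.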

Compound 4, concentration for 50% growth inhibition: 40300 nM
Beside the measured number, compound 4's estimate is 1.5-fold (0.17 log units) above it, within the range that was stated.
By their numbers in this assay, from the lowest: compounds 4, 3 and 2 (each within the scatter of the next). At a limit, above all of these: compound 1.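

Pentyl in place of hydrogen on a selenium, whose other neighbour is an aromatic carbon, now has a measured step in this assay: a 1.3-fold lower number from compound 3 to compound 4 (0.11 log units; within the scatter) shows that this change does not separate the two compounds. Hydrogen in place of benzyl on a nitrogen on an aromatic ring, the other change now measured, gives a 1.8-fold lower number from compound 2 to compound 4 (0.26 log units; within the scatter), so that change does not separate its two compounds either, and neither the pentyl on selenium nor the benzyl on nitrogen can be credited with any shift in this series. The only step here beyond the scatter is an at least 2.4-fold lower number from compound 1 to compound 4 (0.39 log units; beyond the scatter), with one nitrogen atom taking the place of a pentylseleno group, and it is only a floor, since compound 1 stands at a limit and not at a number: the limit of > 100000 nM in this assay, at which 1 of the 4 values shown sits.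

On these data alone, whether a shorter chain such as methyl, a longer chain such as decyl, or a chain ending in a carboxylic acid on the selenium would move the number beyond the scatter stays open. Also open, as far as these compounds go, is whether any other group on the nitrogen, such as a simple acetyl or a morpholine in place of the amine, would separate from compound 4.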